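This account rests on a few compounds, and the source may have more. Where it says the series, first, only, none or still open, it means among the compounds named here.

Compound 1 `O=Cc1ccc(-c2cn3ccnc3c(-c3ccc4ncn(C5CCCCC5)c4c3)n2)cc1` gives 82.2% in a functional assay on UO-31 cells (Homo sapiens) for inhibition, read by sulforhodamine B assay, with a stated time of 48 h, tested at 10 uM; a lower number here means less inhibition, a higher number more inhibition at the concentration tested (going by the name of the read-out). Compound 2 `c1ccc2c(-c3cn4ccnc4c(-c4ccc5ncn(C6CCCCC6)c5c4)n3)cccc2c1` gives 23%. Compound 3 `O=Cc1ccc(-c2cn3ccnc3c(-c3ccc4ncn(Cc5ccccc5)c4c3)n2)cc1` gives 82.2%.

Two changes run through the set. From compound 1 to compound 2 the change is naphthalen-1-yl in place of 4-formylphenyl on an aromatic carbon, and in this assay the step is a number 59.2 percentage points lower from compound 1 to compound 2 (beyond the scatter). From compound 1 to compound 3 the change is benzyl in place of cyclohexyl on an aromatic nitrogen, and the step is no change at the digits printed from compound 1 to compound 3 (within the scatter); compound 3 thus stands level with compound 1.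

Compound 4 `c1ccc(Cn2cnc3ccc(-c4nc(-c5cccc6ccccc56)cn5ccnc45)cc32)cc1` has not been measured. It differs from compound 3 by naphthalen-1-yl in place of 4-formylphenyl on an aromatic carbon, the same change as from compound 1 to compound 2, made on the core of compound 3 rather than that of compound 1. Because the earlier step was a number 59.2 percentage points lower from compound 1 to compound 2 (beyond the scatter), a similar loss is expected, namely a number 58.2 percentage points lower from compound 3 to compound 4 (beyond the scatter). Compound 4 is therefore estimated at 24%, between 8% and 45%.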

Compound 4, a percentage reported as inhibition, at one concentration (the size of the read-out at that concentration, not a potency): 31.3%
For compound 4 the middle estimate is 7.3 percentage points below the measured one; low and high end bracket the measured number.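

In this assay, among the compounds shown here, the exchange of 4-formylphenyl for naphthalen-1-yl carried over to the core of compound 3, the step being a number 50.9 percentage points lower from compound 3 to compound 4 (beyond the scatter), and it matches the earlier step: the same change on two cores in this assay, a number 59.2 percentage points lower (beyond the scatter) from compound 1 to compound 2 and a number 50.9 percentage points lower (beyond the scatter) from compound 3 to compound 4, 8.3 percentage points apart, within the scatter of two such steps The exchange of cyclohexyl for benzyl likewise stayed within the scatter with naphthalen-1-yl in place, the step being a number 8.3 percentage points higher from compound 2 to compound 4 (within the scatter), which also agrees with the earlier step: the same change on two cores in this assay, no change at the digits printed (within the scatter) from compound 1 to compound 3 and a number 8.3 percentage points higher (within the scatter) from compound 2 to compound 4, 8.3 percentage points apart, within the scatter of two such steps This agreement rests on only two cores at a single concentration in one cell line, so it does not show that the change would transfer to other cores, nor why it has this effect.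

From the compounds shown here alone, it remains open whether the formyl group itself matters, since an unsubstituted phenyl, a carboxylic acid or an amine does not appear at that position. Equally open, going by these compounds, is how a longer chain on the aromatic nitrogen would compare with benzyl and cyclohexyl.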